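The source may report more compounds than this note shows. Statements on the series, on what has been measured and on what is new or still open speak of the compounds shown alone.

Measured in a physicochemical assay for solubility, read by HPLC, using the shake flask method, measured as kinetic solubility, with a stated time of 20 h, at pH 6.5, tested at 200 uM; a lower number here means a less soluble compound, a higher number a more soluble compound:
- Compound 1 `O=S(=O)(CCO)c1cccc(-c2ccc3nccc(-c4ccncc4)c3n2)c1`: 55000 nM
- Compound 2 `NS(=O)(=O)c1cccc(-c2ccc3nccc(-c4ccncc4)c3n2)c1`: < 5000 nM (a limit)
- Compound 3 `NS(=O)(=O)c1cccc(-c2ccc3nccc(-c4cccnc4)c3n2)c1`: < 5000 nM (a limit)

Compound 3 gives < 5000 nM, which is a limit of the assay and not a number. This is the limit of < 5000 nM in this assay, at which 2 of the 3 values shown sit.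

Compound 4 `Cc1ccc(-c2ccnc3ccc(-c4cccc(S(N)(=O)=O)c4)nc23)cn1` has methyl in place of hydrogen on an aromatic carbon. Two measured steps lie nearby, but neither tests this change. The large step, an at least 11-fold lower number from compound 1 to compound 2 (1.04 log units; beyond the scatter), altered the group on the sulfonyl sulfur. The other, a step that the two limits leave unreadable from compound 2 to compound 3, swapped pyridin-4-yl for pyridin-3-yl. With so little to go on, no change beyond the scatter is expected, and the expected step is a step that the limit leaves unreadable from compound 3 to compound 4. Compound 4 is estimated at 3500 nM, with an expected range from 1200 nM to 10000 nM.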

Compound 4, solubility: < 5000 nM
Compound 4: only a limit was reported (the forecaster's own chance of this, stated with the estimate: 75%); the middle value lies beyond the limit too.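

No new step can be read among compound 2, compound 3 and compound 4, as each gives only a limit and not a number: the limit of < 5000 nM in this assay, at which 3 of the 4 values shown sit.

On these data alone, whether methyl in place of hydrogen, or pyridin-3-yl in place of pyridin-4-yl, changes the read-out at all stays open.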